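This account rests on a few compounds, and the source may have more. Where it says the series, first, only, none or still open, it means among the compounds named here.

Measured so far:
- compound 1, `O=C1CCC(N2C(=O)c3ccc(Nc4ccccc4)cc3C2=O)C(=O)N1`: 6%
- compound 2, `C=C(OCC)c1ccc(Nc2cccc3c2C(=O)N(C2CCC(=O)NC2=O)C3=O)cc1`: 10%

In an assay on FRT-Jurkat cells for inhibition of nuclear factor NF-kappa-B complex (Homo sapiens), read by flow cytometry, with a stated time of 24 h, tested at 10 uM (on this read-out higher numbers stand for more inhibition at the one concentration tested (going by the name of the read-out) and lower numbers for less inhibition), compound 1 gives 6% and compound 2 gives 10%; the two numbers lie within the usual scatter of each other, so neither stands apart. For the measured compounds named here, no single-change pair among the measured compounds is available, so no measured step size exists for this series.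

Compound 3, `CC(C)(C)c1ccc(Nc2ccc3c(c2)C(=O)N(C2CCC(=O)NC2=O)C3=O)cc1`, is not yet measured. It differs from compound 1 by tert-butyl in place of hydrogen on an aromatic carbon, at the aromatic carbon of the six-membered aromatic ring of carbon only, para to a large group. Nothing measured here speaks to this change. Compound 3 is expected to stay near compound 1, with a step of a number 5 percentage points higher from compound 1 to compound 3 (within the scatter) that is expected to be no larger than the scatter in either direction. The expected value for compound 3 is 11%, in the range 0% to 30%.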

Compound 3, a percentage reported as inhibition, at one concentration (the size of the read-out at that concentration, not a potency): 17%
Beside the measured number, compound 3's estimate is 6 percentage points below it, and the stated range covers the measured number.
By their numbers in this assay, from the lowest: compounds 1, 2 and 3 (each within the scatter of the next, the first and the last beyond it).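

In this assay, tert-butyl in place of hydrogen on an aromatic carbon, para to a large group, gives a number 11 percentage points higher from compound 1 to compound 3 (beyond the scatter). For the compounds shown here, this is the first measured single-change step: the position carries tert-butyl with no loss of inhibition at the one concentration tested, although the step is modest and compound 3 reads only 17%. Nothing measured here gives a reason for the step.

Going by these compounds, with one substituent at this position, it remains open whether the step is particular to tert-butyl or would also appear with a methyl group, a methoxy group, an amine or a carboxylic acid in the same place. Also open, on these data alone, is whether the phenyl to 4-(tert-butyl)phenyl change gives a step of similar size on the core of compound 2.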